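The compounds below may be only part of what the source reports. "The series", "measured", "known", "first", "only" and "open" are said of these compounds alone.

Measured so far: compound 1 `COc1cc(-c2nn(-c3cccc(NC(=O)Nc4ccc(Cl)c(Cl)c4)c3)cc2-c2ccncc2)ccc1Cl`, 570 nM; compound 2 `O=C(Nc1cccc(-n2cc(-c3ccncc3)c(-c3ccc(Cl)c(O)c3)n2)c1)Nc1ccc(Cl)c(Cl)c1`, 730 nM; compound 3 `O=C(Nc1cccc(-n2cc(-c3ccncc3)c(-c3ccc(Cl)c(O)c3)n2)c1)Nc1cc(C(F)(F)F)cc(C(F)(F)F)c1`, 270 nM.

In a functional assay on MDA-MB-468 cells (Homo sapiens) for inhibition, read by sulforhodamine B assay, with a stated time of 48 h (a higher number here means a weaker inhibitor, a lower number a stronger inhibitor), compound 2 stands highest of the three numbers, with compound 1 nearest and compound 3 furthest. Compound 4 `O=C(Nc1cccc(-n2cc(-c3ccncc3)c(-c3ccc(Cl)c(O)c3)n2)c1)Nc1ccc(Cl)c(C(F)(F)F)c1` differs from compound 2 by trifluoromethyl in place of chloro on an aromatic carbon. Within the data shown here, the only measured single step, a 1.3-fold higher number from compound 1 to compound 2 (0.11 log units; within the scatter), concerns a different part of the molecule and does not bear on this change. Compounds 2 and 3, which differ at the same urea-aryl end in more than one place, show a lower number for compound 3. Among the measured compounds shown here, no measured step isolates this change, so compound 4 is expected to move a 1.6-fold lower number from compound 2 to compound 4 (0.21 log units; within the scatter), if at all. Compound 4 is therefore estimated at 450 nM, within 200 nM to 1000 nM.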

Compound 4, half-maximal inhibitory concentration: 540 nM
Beside the measured number, compound 4's estimate is 1.2-fold (0.08 log units) below it, and the stated range covers the measured number.
By their numbers in this assay, from the lowest: compounds 3, 4, 1 and 2 (each within the scatter of the next, the first and the last beyond it).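

In this assay, among these compounds, the change from 3,4-dichlorophenyl to 4-chloro-3-(trifluoromethyl)phenyl gives a 1.4-fold lower number from compound 2 to compound 4 (0.13 log units; within the scatter) and is the first single change read at this end of the molecule. At this aromatic carbon, ortho to a chloro group, four heavy atoms stand in place of one with no shift that can be told from the scatter. Nothing at hand explains this result. The compounds shown leave open how a nitrile, an amine or a carboxylic acid would read at this carbon. They also leave open whether the same exchange would read alike with the methoxy group of compound 1 in place of the hydroxyl group.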